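Microsomal clearance notes: from compound 1 to compound 4

The compounds below may be only part of what the source reports. "The series", "measured", "known", "first", "only" and "open" are said of these compounds alone.

Measured so far:
compound 1 `Cc1c(COc2cccc(OCC3CCOCC3)c2)[nH]c2ccc(-c3cccnc3)cc2c1=O`, 756 mL/min/kg
compound 2 `Cc1c(COc2cc(OCC3CCOCC3)ccn2)[nH]c2ccccc2c1=O`, 113 mL/min/kg
compound 3 `Cc1c(COc2cccc(OCC3CCOCC3)n2)[nH]c2ccccc2c1=O`, 770 mL/min/kg

In an in vitro ADME assay on microsomes from liver (Homo sapiens) for metabolic stability, tested at 0.2 uM (a lower number here means slower removal, a higher number faster removal of the compound), compound 1 gives 756 mL/min/kg, the second highest of the three numbers. Compound 3 sits within the scatter of it, so no order between the two can be claimed; compound 2 lies well below both, beyond the scatter. Compound 4 `Cc1c(COc2cccc(OCC3CCOCC3)c2)[nH]c2ccc(C(=O)O)cc2c1=O` is not yet measured. Its change from compound 1 is a single exchange: carboxy in place of pyridin-3-yl on an aromatic carbon. Going by the values given here, no step between measured compounds covers this exchange, so the expectation rests on the spread already seen, where compound 2, with 113 mL/min/kg, shows that values can come far lower than compound 1. A clear drop is expected, with the estimated step of a 6.3-fold lower number from compound 1 to compound 4 (0.80 log units; beyond the scatter) reaching beyond the scatter. Compound 4 is therefore estimated at 120 mL/min/kg, with a range from 30 mL/min/kg to 450 mL/min/kg.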

Compound 4, clearance: < 20 mL/min/kg
Compound 4: no number, only a limit; the forecaster's own chance of this, stated with the estimate: 10%; at least 6.0-fold (0.77 log units) between middle value and limit.
By their numbers in this assay, from the lowest: compound 2; then compounds 1 and 3 (each within the scatter of the next). At a limit, below all of these: compound 4.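

Carboxy in place of pyridin-3-yl on an aromatic carbon gives an at least 37-fold lower number from compound 1 to compound 4 (1.57 log units; beyond the scatter) in this assay. Going by these compounds alone, this is the first measured step, and it shows that a single exchange at this position of the shared core can move clearance by a large margin. Compound 4 gives no number, only a limit of the assay: the limit of < 20 mL/min/kg in this assay, at which 1 of the 4 values shown sits.

The compounds shown leave open whether the drop follows the arrival of carboxy or the departure of pyridin-3-yl. A primary amide or a methyl ester on the same carbon would bear on that question.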